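The source may hold more compounds than are shown below. What is called first, only, known or untested is meant among the compounds shown, and "the series" means these compounds.

Compound 3 `C[C@@H](NC(=O)Nc1ccc(Br)cc1)c1ccccc1` gives 95% in an ADME assay on the whole organism with Oryza sativa as the target, tested at 1 uM; on this read-out higher numbers stand for a weaker effect at the one concentration tested and lower numbers for a stronger effect. Among the three measured compounds it stands together with compound 2 `C[C@H](NC(=O)Nc1ccc(F)cc1)c1ccccc1`, whose 97% lies within the usual scatter of it, while compound 1 `CCCCc1ccc(NC(=O)N[C@@H](C)c2ccccc2)cc1`, with 72%, sits clearly apart. Going by the values given here, the one measured step, a number 25 percentage points higher from compound 1 to compound 2 (beyond the scatter), concerns a group on an aromatic carbon and not the configuration of a stereocentre. Compound 4 `C[C@H](NC(=O)Nc1ccc(Br)cc1)c1ccccc1` differs from compound 3 only as follows: the two compounds have the same atoms and bonds and differ only in configuration as drawn: 1 of 1 stereo elements differ; a stereocentre at a saturated chain carbon is drawn R in compound 3 and S in compound 4. Among the compounds with values here, no measured step bears on such a change, so no step beyond the scatter is expected in this assay, and compound 4 is estimated at 93%, between 75% and 100%, which means an expected step of a number 2 percentage points lower from compound 3 to compound 4 (within the scatter).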

Compound 4, a percentage reported as activity, at one concentration (the size of the read-out at that concentration, not a potency): 97%
For compound 4 the middle estimate is 4 percentage points below the measured one; the range from low to high includes it.
By their numbers in this assay, from the lowest: compound 1; then compounds 3, 2 and 4 (each within the scatter of the next).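

In this assay, the stereocentre at the saturated chain carbon can be read on its own, and the change gives a number 2 percentage points higher from compound 3 to compound 4 (within the scatter): the fact that compounds 3 and 4 differ only in the configuration as drawn. Bromo in place of fluoro on an aromatic carbon gives no change at the digits printed from compound 2 to compound 4 (within the scatter), whereas bromo in place of butyl gives a number 25 percentage points higher from compound 1 to compound 4 (beyond the scatter), so among these compounds only compound 1 stands apart. On these data alone, what the configuration does when butyl sits on the aromatic carbon stays open, as does what a longer chain, a methoxy group or a carboxylic acid there would give.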